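A few compounds are considered here, and "the series" means these few. Any claim that something is new, unique, unknown or untested is made for them only; others in the source may bear on it.

- Compound 1 `CC1(C)[C@H]2CC[C@]1(C)N(Cc1cn(-c3cccc(Cl)c3)nn1)C(=O)C2`: 60 nM
- Compound 2 `CC1(C)[C@H]2CC[C@]1(C)N(Cc1cn(-c3ccccc3)nn1)C(=O)C2`: 70 nM

In a functional assay on A549 cells (Homo sapiens) for inhibition, read by MTT assay, with a stated time of 24 h (a higher number here means a weaker inhibitor, a lower number a stronger inhibitor), the two measured compounds cannot be told apart. Among the compounds with values here, compound 2, at 70 nM, therefore stands level with its only measured neighbour. The next compound, compound 3 (`CC1(C)[C@H]2CC[C@]1(C)N(Cc1cn(-c3ccccc3O)nn1)C(=O)C2`), differs from compound 2 at one place: hydroxy in place of hydrogen on an aromatic carbon. This is hydroxy in place of hydrogen on an aromatic carbon, ortho to a large group, so phenyl becomes 2-hydroxyphenyl.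

Within the data shown here, only one measured step bears on this change, the exchange of chloro for hydrogen on an aromatic carbon, which gave a 1.2-fold higher number from compound 1 to compound 2 (0.07 log units; within the scatter). Among the measured compounds shown here, it is weak guidance, since it involves a different group and no measured compound carries a hydroxy. On the strength of that one small step, no change beyond the scatter is expected in either direction, although the range must stay wide. The expected step is a 1.1-fold higher number from compound 2 to compound 3 (0.06 log units; within the scatter). For compound 3 the estimated value is 80 nM, with an expected range from 25 nM to 250 nM.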

Compound 3, half-maximal inhibitory concentration: 230 nM
Beside the measured number, compound 3's estimate is 2.9-fold (0.46 log units) below it; the range from low to high includes it.
By their numbers in this assay, from the lowest: compounds 1 and 2 (each within the scatter of the next); then compound 3.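

In this assay, hydroxy on an aromatic carbon ortho to a large group gives a 3.3-fold higher number from compound 2 to compound 3 (0.52 log units; beyond the scatter), so this position responds to substitution in a way the earlier chloro exchange did not reveal, since a 1.2-fold higher number from compound 1 to compound 2 (0.07 log units; within the scatter) stayed within the scatter. Compound 3 also separates from the chloro compound, with 2-hydroxyphenyl in place of 3-chlorophenyl on the aromatic nitrogen giving a 3.8-fold higher number from compound 1 to compound 3 (0.58 log units; beyond the scatter), which makes compound 3 the weakest inhibitor of the three, although both steps are modest. No supporting measurement is available to explain why this change weakens inhibition.

The three compounds leave open whether the step belongs to hydroxy as a group or to its place on the ring, as no other compound shown carries hydroxy elsewhere on the six-membered aromatic ring. They also leave open whether methoxy, an amine or a fluorine atom at the same place, ortho to a large group, would give a step of similar size or stay within the scatter.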